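The source may hold more compounds than are shown below. What is called first, only, known or untested is meant among the compounds shown, and "the series" means these compounds.

Measured so far in a toxicity assay on THP-1 cells (Homo sapiens) for inhibition; on this read-out lower numbers stand for higher toxicity in this test and higher numbers for lower toxicity in this test:
Compound 1 `COc1ccc(-c2cnc(NC(=O)CCc3ccccc3)n2C)cc1` gives > 100000 nM, a limit of the assay.
Compound 2 `COc1ccc(-c2cnc(NC(=O)c3ccc(F)cc3)n2C)cc1` gives >= 50000 nM, a limit of the assay.
Compound 3 `COc1ccc(-c2cnc(NC(=O)C3CCNCC3)n2C)cc1` gives > 100000 nM, again a limit rather than a number.

Compound 3 therefore stands at the top of what this assay reports, shared with the limit of > 100000 nM in this assay, at which 2 of the 3 values shown sit, and close to the limit of >= 50000 nM in this assay, at which 1 of the 3 values shown sits. Compound 4 `COc1ccc(-c2cnc(NC(=O)c3ccno3)n2C)cc1` differs from compound 3 by 1,2-oxazol-5-yl in place of piperidin-4-yl on a carbonyl carbon. Within the data shown here, the steps that bear on this change, a step that the two limits leave unreadable from compound 1 to compound 3 and a step that the two limits leave unreadable from compound 2 to compound 3, both sit between limits, so their size cannot be read, and no measured step shows any change beyond the scatter. The writer therefore expects no step beyond the scatter, a number no higher from compound 3 to compound 4 (the limit leaves the size open), and estimates compound 4 at 100000 nM, between 50000 nM and 200000 nM, most likely reported as a limit.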

Compound 4, half-maximal cytotoxic concentration: > 100000 nM
Compound 4 ended at the assay's limit; the forecaster's own chance of this, stated with the estimate: 85%; the middle value lies on the limit itself.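

Compound 4, like compound 1, compound 2 and compound 3, gives only a limit in this assay, so no step among these compounds can be read. The compounds shown leave open whether any group on the carbonyl carbon changes toxicity in this test at all.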